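The source may report more compounds than this note shows. Statements on the series, on what has been measured and on what is new or still open speak of the compounds shown alone.

Compound 1, `CC(C(=O)NCc1ccc(C(C)(C)C)nc1OC1CCCC1)c1ccc(NS(C)(=O)=O)c(F)c1`, is the anchor of this small set. Within the data shown here, in an assay on cells for antagonist activity at transient receptor potential cation channel subfamily V member 1 (Homo sapiens), read by FLIPR and calcium flux, with a stated time of 6 min (on this read-out lower numbers stand for stronger inhibition and higher numbers for weaker inhibition), compound 1 gives 1.5 nM, the lowest of the three numbers measured so far. Compound 2, `CCCCCSc1nc(C(C)(C)C)ccc1CNC(=O)C(C)c1ccc(NS(C)(=O)=O)c(F)c1`, gives 3.1 nM, and compound 3, `CC(C(=O)NCc1ccc(C(C)(C)C)nc1SCc1ccccc1Cl)c1ccc(NS(C)(=O)=O)c(F)c1`, gives 3.8 nM. Each of them differs from compound 1 at a single aromatic carbon of the shared core: a 2.1-fold higher number from compound 1 to compound 2 (0.32 log units; beyond the scatter), and a 2.5-fold higher number from compound 1 to compound 3 (0.40 log units; beyond the scatter). Between the two sulfur-bearing chains themselves the gap is small, a 1.2-fold higher number from compound 2 to compound 3 (0.09 log units; within the scatter).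

Compound 4, `CCCCCc1nc(C(C)(C)C)ccc1CNC(=O)C(C)c1ccc(NS(C)(=O)=O)c(F)c1`, has not yet been measured. It differs from compound 1 at that same aromatic carbon: pentyl in place of cyclopentyloxy on an aromatic carbon. Among the measured compounds shown here, the closest measured step is the one from compound 1 to compound 2, where a pentyl chain attached through sulfur took the place of the same cyclopentyloxy group and the number rose modestly; the step from compound 1 to compound 3 moved in the same direction by a similar amount. For the measured compounds named here, compound 4 carries the pentyl chain directly, without a linking atom, and no measured pair tests exactly that. Compound 2 gave 3.1 nM for the nearest change, so for compound 4 a modest rise beyond the scatter is expected, a 2.1-fold higher number from compound 1 to compound 4 (0.33 log units; beyond the scatter). Compound 4 is estimated at 3.2 nM, with a likely range from 1.2 nM to 8.5 nM.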

Compound 4, inhibition constant: 1.9 nM
Estimate against measurement, compound 4: 1.7-fold (0.23 log units) above, within the range that was stated.
By their numbers in this assay, from the lowest: compounds 1, 4, 2 and 3 (each within the scatter of the next, the first and the last beyond it).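

In this assay pentyl on this aromatic carbon next to the ring nitrogen reads much like cyclopentyloxy (a 1.3-fold higher number from compound 1 to compound 4 (0.10 log units; within the scatter)), even though the swap removes both the five-membered ring and the oxygen, the one hydrogen-bond acceptor of the group that leaves. Compounds 1, 2 and 3 all joined their side group to the core through oxygen or sulfur, whereas compound 4 shows that a number in this same low range does not need such a linking atom: the direct pentyl chain stays within the scatter of the pentylsulfanyl group (a 1.6-fold lower number from compound 2 to compound 4 (0.21 log units; within the scatter)) and of the (2-chlorobenzyl)sulfanyl group (a 2.0-fold lower number from compound 3 to compound 4 (0.30 log units; within the scatter)), and, unlike those two groups, also within the scatter of cyclopentyloxy. Nothing available here explains why these groups read so alike.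

Still open, as far as these compounds go, is how short or long the carbon chain can be at this position, from a methyl group to an octyl chain. Also open, from the compounds shown here alone, is how an amine or a carboxylic acid at the end of the pentyl chain would read.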